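The compounds below may be only part of what the source reports. "The series", "measured", "known", "first", "only" and "open" are said of these compounds alone.

Measured so far:
- compound 1 `O=C(NCc1ccc(S(=O)(=O)N2CCCCC2)cc1)c1cc2cnccc2o1`: 1500 nM
- compound 2 `O=C(NCc1ccc(S(=O)(=O)N2CCCCC2)cc1)c1cc2ccncc2[nH]1`: 1700 nM
- compound 3 `O=C(NCc1ccc(S(=O)(=O)c2ccccc2)cc1)c1c[nH]c2ccncc12`: 2100 nM

All values come from a functional assay on A2780 cells (Homo sapiens) for inhibition, read by sulforhodamine B assay, with a stated time of 72 h; a lower number here means a stronger inhibitor, a higher number a weaker inhibitor. Compound 2, at 1700 nM, lies within the scatter of both compound 1 and compound 3, so the three are not separated.

Compound 4 `O=C(NCc1ccc(S(=O)(=O)N2CCCCC2)cc1)c1ccn2ccnc2c1` has the same atoms as compound 2, joined differently: a group of 9 heavy atoms (7 carbon, 2 nitrogen; one five-membered aromatic ring with 2 hetero atoms, one six-membered aromatic ring with 1 hetero atom) in place of a group of 9 heavy atoms (7 carbon, 2 nitrogen; one five-membered aromatic ring with 1 hetero atom, one six-membered aromatic ring with 1 hetero atom), on a carbonyl carbon. Among the measured compounds shown here, the only measured step that bears on this is at the same carbonyl carbon: a 1.1-fold higher number from compound 1 to compound 2 (0.05 log units; within the scatter). For the measured compounds named here, that step stayed within the scatter, so no step beyond the scatter is expected in this assay, though no measured step covers this exact swap. The expected change is a 1.2-fold higher number from compound 2 to compound 4 (0.07 log units; within the scatter). The estimate for compound 4 is 2000 nM, with an expected range of 500 nM to 8000 nM.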

Compound 4, half-maximal inhibitory concentration: > 10000 nM
Compound 4: a limit, no number; the forecaster's own chance of this, stated with the estimate: 15%; middle value at least 5.0-fold (0.69 log units) from the limit.
By their numbers in this assay, from the lowest: compounds 1, 2 and 3 (each within the scatter of the next). At a limit, above all of these: compound 4.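

At the carbonyl carbon, the choice of fused pair matters even with the same atoms, joined differently: the step is an at least 5.8-fold higher number from compound 2 to compound 4 (0.76 log units; beyond the scatter), and an at least 6.6-fold higher number from compound 1 to compound 4 (0.82 log units; beyond the scatter). The earlier swap at this place gave no such separation. Compound 4 stands at a limit, not a number: the limit of > 10000 nM in this assay, at which 1 of the 4 values shown sits.

On these data alone, how far compound 4 lies past that limit stays open, and the ring change and the hydrogen-bond counts move together in this one swap, so neither can be singled out. Also open, as far as these compounds go, is whether an amine or a carboxylic acid on the entering group would change the reading.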